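The source may report more compounds than this note shows. Statements on the series, on what has been measured and on what is new or still open speak of the compounds shown alone.

Going by the values given here, in a functional assay on MCF7 cells (Homo sapiens) for cytotoxicity, read by MTT assay, with a stated time of 72 h (a lower number here means a stronger inhibitor, a higher number a weaker inhibitor), compound 2 `O=C1N/C(=N/c2csc(-c3ccc(Cl)cc3)c2)S/C1=C\c1ccc(Br)cc1` gives 2500 nM, the higher of the two numbers so far, while compound 1 `Cc1ccc(/C=C2\S/C(=N\c3csc(-c4ccc(Cl)cc4)c3)NC2=O)cc1` gives 900 nM. Compound 3 `O=C1N/C(=N/c2csc(-c3ccc(Cl)cc3)c2)S/C1=C\c1ccccn1` departs from compound 2 by one change: pyridin-2-yl in place of 4-bromophenyl on a double-bonded chain carbon bound to a double-bonded ring carbon. Among the compounds with values here, the only measured step, a 2.8-fold higher number from compound 1 to compound 2 (0.44 log units; beyond the scatter), is modest, puts bromo in place of methyl on an aromatic carbon, and bears on this change only loosely. Within the data shown here, no measured compound carries pyridin-2-yl. A similarly modest move toward a lower number is expected, a 1.7-fold lower number from compound 2 to compound 3 (0.22 log units; within the scatter). For compound 3 the estimated value is 1500 nM, with an expected range of 500 nM to 4500 nM.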

Compound 3, half-maximal inhibitory concentration: 30200 nM
Estimate against measurement, compound 3: 20-fold (1.30 log units) below; measured number outside the range, above it.
By their numbers in this assay, from the lowest: compound 1; then compound 2; then compound 3.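

In this assay, this position on the double-bonded chain carbon tolerates a change of ring far less well than a change of substituent: pyridin-2-yl in place of 4-bromophenyl gives a 12-fold higher number from compound 2 to compound 3 (1.08 log units; beyond the scatter), and pyridin-2-yl in place of 4-methylphenyl gives a 34-fold higher number from compound 1 to compound 3 (1.53 log units; beyond the scatter). Both steps are large, whereas the exchange of methyl for bromo was modest. No measurement shown accounts for this rise. The compounds shown leave open whether the rise goes with the ring nitrogen or with the missing bromo or methyl group, and where a plain phenyl or a methoxyphenyl would stand.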